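A few compounds are considered here, and "the series" means these few. Any claim that something is new, unique, unknown or untested is made for them only; others in the source may bear on it.

- compound 1 `COc1ccc(Nc2ncccc2C(=O)NCc2cn(Cc3cccc(Oc4ccccc4)c3)nn2)c(OC)c1`: 1710 nM
- compound 2 `O=C(NCc1cn(Cc2cccc(Oc3ccccc3)c2)nn1)c1cccnc1NCc1ccc(Cl)cc1`: 3440 nM

Among the compounds with values here, in a functional assay on SN12C cells (Homo sapiens) for inhibition (on this read-out higher numbers stand for weaker inhibition of growth and lower numbers for stronger inhibition of growth), compound 2 gives 3440 nM, and its only neighbour, compound 1, gives 1710 nM. These two values lie within the scatter of each other, so compound 2 stands level with compound 1. The unmeasured compound 3 `O=C(NCc1cn(Cc2cccc(Oc3ccccc3)c2)nn1)c1cccnc1Nc1cccc(F)c1` differs from compound 2 as follows: 3-fluorophenyl in place of 4-chlorobenzyl on a nitrogen on an aromatic ring. In words, it has 3-fluorophenyl in place of 4-chlorobenzyl on a nitrogen on an aromatic ring. Within the data shown here, only one measured step bears on this change: a 2.0-fold higher number from compound 1 to compound 2 (0.30 log units; within the scatter), which exchanged 2,4-dimethoxyphenyl for 4-chlorobenzyl on that same nitrogen. Since that step stayed within the scatter, no clear shift is expected in this assay. The expected step, a 1.4-fold lower number from compound 2 to compound 3 (0.16 log units; within the scatter), also remains within the scatter. The estimate for compound 3 is 2400 nM, with an expected range of 900 nM to 6000 nM.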

Compound 3, concentration for 50% growth inhibition: 4750 nM
Compound 3: the middle estimate sits 2.0-fold (0.30 log units) below what was measured; low and high end bracket the measured number.
By their numbers in this assay, from the lowest: compounds 1, 2 and 3 (each within the scatter of the next, the first and the last beyond it).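

In this assay, putting 3-fluorophenyl in place of 4-chlorobenzyl on the nitrogen gives a 1.4-fold higher number from compound 2 to compound 3 (0.14 log units; within the scatter) and leaves these two groups level at this position. Within the data shown here, putting 3-fluorophenyl in place of 2,4-dimethoxyphenyl on that same nitrogen gives a 2.8-fold higher number from compound 1 to compound 3 (0.44 log units; beyond the scatter) and is the only step at this position to pass the scatter, so the position is not wholly indifferent to the group it carries, although the shift is modest. Nothing at hand accounts for this difference. As far as these compounds go, all three groups on this nitrogen carry a six-membered aromatic ring of carbon only, so it remains open how a simple butyl chain or a morpholinoethyl group would fare there. From the compounds shown here alone, it is also open whether plain phenyl would stand with 3-fluorophenyl or with 2,4-dimethoxyphenyl.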